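The source may hold more compounds than are shown below. What is called first, only, known or untested is meant among the compounds shown, and "the series" means these compounds.

Among the compounds with values here, in a functional assay on M14 cells (Homo sapiens) for cytotoxicity (a lower number here means a stronger inhibitor of growth, a higher number a weaker inhibitor of growth), compound 2 `CSc1ccc(C2=C(c3ccc(F)c(C)c3)C(=O)N3CCCC3C2)cc1` gives 800 nM, the only true number so far. Compound 1 `COc1ccc(C2=C(c3cc(OC)c(OC)c(OC)c3)CC3CCCN3C2=O)cc1O` gives only a limit, > 100000 nM. Compound 3 `CSc1ccc(C2=C(c3ccc(C)cc3)C(=O)N3CCCC3C2)cc1` keeps the shared core and the 4-(methylsulfanyl)phenyl group of compound 2, and it differs in one group: 4-methylphenyl in place of 4-fluoro-3-methylphenyl on a double-bonded ring carbon. In short, it carries 4-methylphenyl in place of 4-fluoro-3-methylphenyl on a double-bonded ring carbon. Within the data shown here, no two measured compounds differ in just one place, so the data offer no direct guide to the size of this change. The expected step of a 1.5-fold higher number from compound 2 to compound 3 (0.18 log units; within the scatter) in this assay is small, a slight weakening if anything, and probably no larger than the usual scatter. Compound 3 is therefore estimated at 1200 nM, with an expected range from 350 nM to 5000 nM.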

Compound 3, concentration for 50% growth inhibition: 6000 nM
For compound 3 the middle estimate is 5.0-fold (0.70 log units) below the measured one; measured number above the stated range.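

In this assay, within the data shown here, the swap of 4-fluoro-3-methylphenyl for 4-methylphenyl gives a 7.5-fold higher number from compound 2 to compound 3 (0.88 log units; beyond the scatter), the first step that can be read from a pair differing in one place. It shows that growth inhibition responds to the group on this double-bonded ring carbon, even when the six-membered aromatic ring of carbon stays and the rest of the molecule is unchanged. The values shown give no cause for this weakening.

Still open, as far as these compounds go, is which part of the 4-fluoro-3-methylphenyl group matters, a question that 4-fluorophenyl and 3-methylphenyl groups at this position could help to separate. Also open, from the compounds shown here alone, is how a ring carrying an amine or a carboxylic acid would behave here.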